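This account rests on a few compounds, and the source may have more. Where it says the series, first, only, none or still open, it means among the compounds named here.

In an ADME assay on MRC5 cells (Homo sapiens) for cytotoxicity, read by MTT assay, with a stated time of 72 h (on this read-out higher numbers stand for lower toxicity in this test and lower numbers for higher toxicity in this test), compound 1 `OC[C@H]1O[C@@H](n2cc(F)c3c(-c4ccccc4)ncnc32)[C@H](O)[C@@H]1O` gives > 50000 nM, which is a limit of the assay and not a number. Among the compounds with values here, compound 2 `OC[C@H]1O[C@@H](n2cc(F)c3c(-c4ccco4)ncnc32)[C@H](O)[C@@H]1O` gives 29000 nM, the only actual number so far. Compound 3 `OC[C@H]1O[C@@H](n2cc(F)c3c(-c4ccoc4)ncnc32)[C@H](O)[C@@H]1O` has the same atoms joined differently, with furan-3-yl in place of furan-2-yl on an aromatic carbon. Within the data shown here, no measured step covers this exchange directly. The nearest evidence is the exchange of phenyl for furan-2-yl at the same place, which gives an at least 1.7-fold lower number from compound 1 to compound 2 (0.23 log units; that floor lies within the scatter). That floor lies within the scatter, and it is set by the limit of > 50000 nM in this assay, at which 1 of the 2 values shown sits. With compound 2 as the starting point, no change beyond the scatter is therefore expected in this assay, and the expected step is a 1.0-fold lower number from compound 2 to compound 3 (0.02 log units; within the scatter). For compound 3, the estimated value is 28000 nM, with an expected range from 12000 nM to 60000 nM.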

Compound 3, half-maximal cytotoxic concentration: 15400 nM
Compound 3: middle estimate off by 1.8-fold (0.26 log units), on the high side; the measured number falls inside the stated range.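

In this assay, the exchange of furan-2-yl for furan-3-yl gives a 1.9-fold lower number from compound 2 to compound 3 (0.27 log units; within the scatter), so the two furan attachments cannot be told apart at this position in this test. Within the data shown here, the exchange of phenyl for furan-3-yl gives an at least 3.2-fold lower number from compound 1 to compound 3 (0.51 log units; beyond the scatter), the first step at this position that is printed as beyond the scatter, which the step to the furan-2-yl compound was not. That step is only a floor and its full size stays unknown, because compound 1 stands at a limit of the assay and not at a number: the limit of > 50000 nM in this assay, at which 1 of the 3 values shown sits.

The compounds shown leave open how a thienyl ring, a pyridyl ring, an amine or a short alkyl chain on the same aromatic carbon would read in this assay. They also leave open how far the phenyl compound truly lies from the two furan compounds.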